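A Methyl on the Shared Core of Compound 1

The source may report more compounds than this note shows. Statements on the series, on what has been measured and on what is new or still open speak of the compounds shown alone.

Measured so far in a functional assay on NCI-H1975 cells (Homo sapiens) for antiproliferative activity, read by MTT assay, with a stated time of 72 h; a lower number here means a stronger inhibitor, a higher number a weaker inhibitor:
Compound 1 `COc1cc(N(C)CCN(C)C)c(NC(=O)/C=C\C(C)C)cc1Nc1nccc(-c2cn(C)c3ccccc23)n1` gives 1820 nM.
Compound 2 `CCC/C=C\C(=O)Nc1cc(Nc2nccc(-c3cn(C)c4ccccc34)n2)c(OC)cc1N(C)CCN(C)C` gives 1220 nM.

Compound 1 has only one neighbour among the numbers shown, and the step of a 1.5-fold lower number from compound 1 to compound 2 (0.17 log units; within the scatter) lies within the scatter, so the two cannot be ordered. Compound 3 `COc1cc(N(C)CCN(C)C)c(NC(=O)/C=C\C(C)C)cc1Nc1nc(C)cc(-c2cn(C)c3ccccc23)n1` differs from compound 1 by methyl in place of hydrogen on an aromatic carbon. Going by the values given here, the one measured step alters the chain on the amide, not the shared core, so these numbers give no direction for the change at hand. Expected, then, is a 1.0-fold lower number from compound 1 to compound 3 (0.00 log units; within the scatter), nothing beyond the scatter. Compound 3 is estimated at 1800 nM, with a range from 700 nM to 4500 nM.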

Compound 3, half-maximal inhibitory concentration: 1230 nM
Estimate against measurement, compound 3: 1.5-fold (0.17 log units) above; the measured number falls inside the stated range.
By their numbers in this assay, from the lowest: compounds 2, 3 and 1 (each within the scatter of the next).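

Methyl in place of hydrogen on an aromatic carbon, next to the ring nitrogen, gives a 1.5-fold lower number from compound 1 to compound 3 (0.17 log units; within the scatter) in this assay and so leaves the number within the scatter of compound 1. Going by these compounds alone, this is the first measured step on the shared core rather than on the chain of the amide, and it shows that this position accepts a methyl with no readable shift. No available evidence bears on this result. Going by these compounds, whether an amine, a carboxylic acid or a longer chain at this position would move the number beyond the scatter remains open.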